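Triazole thioacetamide oximes: paw edema notes

A few compounds are considered here, and "the series" means these few. Any claim that something is new, unique, unknown or untested is made for them only; others in the source may bear on it.

Compound 1 `C/C(=N\O)c1ccc(NC(=O)CSc2nnc(-c3ccccc3)n2-c2ccccc2)cc1` gives 66% in a functional assay on the whole organism (strain albino) for inhibition, with Rattus norvegicus as the target, read by paw edema, with stated times of 30 min and 5 h, at a dose of 0.28 mmol/kg by the oral route; on this read-out lower numbers stand for less inhibition and higher numbers for more inhibition at the one dose given (going by the name of the read-out). Compound 3 `COc1ccc(-c2nnc(SCC(=O)Nc3ccc(/C(C)=N/O)cc3)n2-c2ccccc2)cc1` differs from compound 1 by methoxy in place of hydrogen on an aromatic carbon. In this assay compound 3 gives 58%; the step is a number 8 percentage points lower from compound 1 to compound 3 (within the scatter). Compound 2 `CCn1c(SCC(=O)Nc2ccc(/C(C)=N/O)cc2)nnc1-c1ccc(OC)c(OC)c1` carries another core; the difference between the two cores is not broken down here. In this assay compound 2 gives 73%. Compound 4 `CCn1c(SCC(=O)Nc2ccc(/C(C)=N/O)cc2)nnc1-c1cc(OC)c(OC)c(OC)c1` differs from compound 2 by methoxy in place of hydrogen on an aromatic carbon. This is the same kind of change as that from compound 1 to compound 3, not the same: there the entering group sat para to a large group, here it sits ortho to a methoxy group, meta to a large group and meta to a methoxy group. The step expected in this assay is a number 5 percentage points lower from compound 2 to compound 4 (within the scatter), resting on the earlier change, which gave a number 8 percentage points lower from compound 1 to compound 3 (within the scatter). Compound 4 is expected to give 68%, estimated between 55% and 80%.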

Compound 4, a percentage reported as inhibition, in the whole organism at one dose (the size of the read-out at that dose, not a potency): 61%
The estimate for compound 4 lay 7 percentage points above the measured number, within the range that was stated.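

In this assay the entering methoxy gives a number 12 percentage points lower from compound 2 to compound 4 (beyond the scatter). Set beside the earlier step on the other core, the change shows no detectable difference between the two cores: the same change on two cores in this assay, a number 8 percentage points lower (within the scatter) from compound 1 to compound 3 and a number 12 percentage points lower (beyond the scatter) from compound 2 to compound 4, 4 percentage points apart, within the scatter of two such steps

Among the compounds shown here, this rests on two pairs only, with the methoxy entering at different places on the ring and only one of the two steps lying beyond the scatter, so it supports a shared direction at one dose, not a fixed step size or a rule for other cores. Still open, on these data alone, is how an amine or a carboxylic acid would read at the same aromatic carbon. Also open, as far as these compounds go, is whether a longer chain on the core of compound 2 would alter the step.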